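This account rests on a few compounds, and the source may have more. Where it says the series, first, only, none or still open, it means among the compounds named here.

Measured so far:
compound 1 `N#C[C@@]1(NC(=O)[C@@H](CC(=O)N2CCOCC2)CC2CCCCC2)CCN(C2CCCC2)C1`: 75 nM
compound 2 `CC(C)N1CC[C@@](C#N)(NC(=O)[C@@H](CC(=O)N2CCOCC2)CC2CCCCC2)C1`: 66 nM
compound 3 `CN1CCC(C#N)(NC(=O)[C@@H](CC(=O)N2CCOCC2)CC2CCCCC2)CC1`: 251 nM

In an assay on isolated protein for inhibition of cathepsin S (Homo sapiens) (on this read-out higher numbers stand for weaker inhibition and lower numbers for stronger inhibition), compound 3 gives the highest number of the three, so it is the weakest inhibitor here. Compound 4 `CN1CC[C@@](C#N)(NC(=O)[C@@H](CC(=O)N2CCOCC2)CC2CCCCC2)C1` is not yet measured. It differs from compound 3 in one place (3-cyano-1-methylpyrrolidin-3-yl in place of 4-cyano-1-methylpiperidin-4-yl on an amide-type nitrogen). For the measured compounds named here, two measured steps bear on this. The step of a 3.8-fold higher number from compound 2 to compound 3 (0.58 log units; beyond the scatter) combined a change of ring and of the group on the ring nitrogen. The step of a 1.1-fold lower number from compound 1 to compound 2 (0.06 log units; within the scatter) shows that changing only the group on that nitrogen barely matters. The ring change itself therefore seems to carry the weakening seen, so undoing it is expected to strengthen inhibition: compound 4 is estimated to give 80 nM (range 40 nM to 160 nM), a step of a 3.1-fold lower number from compound 3 to compound 4 (0.50 log units; beyond the scatter).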

Compound 4, half-maximal inhibitory concentration: 155 nM
The estimate for compound 4 lay 1.9-fold (0.29 log units) below the measured number; low and high end bracket the measured number.
By their numbers in this assay, from the lowest: compounds 2 and 1 (each within the scatter of the next); then compounds 4 and 3 (each within the scatter of the next).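

With the methyl group held fixed, the ring swap on the amide-type nitrogen stays within the scatter in this assay (a 1.6-fold lower number from compound 3 to compound 4 (0.21 log units; within the scatter)), so ring size does not separate these two compounds. Isopropyl and cyclopentyl on the ring nitrogen could not be told apart, but methyl can be told apart from both, modestly, in place of isopropyl (a 2.3-fold higher number from compound 2 to compound 4 (0.37 log units; beyond the scatter)) and in place of cyclopentyl (a 2.1-fold higher number from compound 1 to compound 4 (0.32 log units; beyond the scatter)). Nothing measured here gives a reason for these steps. The compounds shown leave open where between methyl and isopropyl the change sets in, as an ethyl group on that nitrogen would show, and how a bare nitrogen carrying only hydrogen would compare.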